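The source may report more compounds than this note shows. Statements on the series, on what has been measured and on what is new or still open speak of the compounds shown alone.

Three measured compounds share one core. Compound 1 `O=C1/C(=C/c2ccccc2)CCC/C1=C\c1cccc([N+](=O)[O-])c1` carries an unsubstituted phenyl on one arm, and in a functional assay on MOLT-4 cells (Homo sapiens) for cytotoxicity, with a stated time of 72 h (on this read-out lower numbers stand for stronger inhibition and higher numbers for weaker inhibition), compound 1 gives 1700 nM. Compound 2 `Cc1ccc(/C=C2\CCC/C(=C\c3cccc([N+](=O)[O-])c3)C2=O)cc1`, which adds a methyl to that phenyl, gives 9530 nM in this assay, the highest of the three numbers. Compound 3 `O=C1CCCC/C1=C\c1cccc([N+](=O)[O-])c1`, which lacks the phenyl arm altogether, gives 8280 nM in this assay, and its number and that of compound 2 lie within the scatter of each other. Going by the values given here, the one measured step that bears on the question is a 5.6-fold higher number from compound 1 to compound 2 (0.75 log units; beyond the scatter). Compound 4 `O=C1/C(=C/c2ccc(F)cc2)CCC/C1=C\c1cccc([N+](=O)[O-])c1` differs from compound 2 by fluoro in place of methyl on an aromatic carbon. Among the compounds with values here, no measured pair shows what fluoro does at this place; the only guide is that taking the methyl away, as in compound 1 with 1700 nM, gave a lower number. The number for compound 4 is therefore expected to move by a 2.7-fold lower number from compound 2 to compound 4 (0.44 log units; beyond the scatter). That would leave compound 4 well short of compound 1, since nothing measured says fluoro behaves like hydrogen here. The estimate for compound 4 in this assay is 3500 nM, with a likely range from 1200 nM to 10000 nM.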

Compound 4, half-maximal inhibitory concentration: 5120 nM
For compound 4 the middle estimate is 1.5-fold (0.17 log units) below the measured one; the range from low to high includes it.
By their numbers in this assay, from the lowest: compound 1; then compounds 4, 3 and 2 (each within the scatter of the next).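

In this assay, fluoro in place of methyl gives a 1.9-fold lower number from compound 2 to compound 4 (0.27 log units; within the scatter), a step within the scatter, so the two groups cannot be told apart at this place, para to a large group. Fluoro in place of hydrogen gives a 3.0-fold higher number from compound 1 to compound 4 (0.48 log units; beyond the scatter), which is beyond the scatter, so among these compounds the unsubstituted phenyl of compound 1 is not matched by either of the two groups tried here, methyl or fluoro. Nothing measured on these compounds explains this difference.

From the compounds shown here alone, it remains open whether any other group at this place, such as a methoxy, an amine or a carboxylic acid, would give a number close to that of compound 1 or one further from it. Going by these compounds, it is also open whether fluoro or methyl would behave the same way on another carbon of that phenyl ring.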